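Cyclohexyl to methyl on the side chain: working notes

The compounds below may be only part of what the source reports. "The series", "measured", "known", "first", "only" and "open" are said of these compounds alone.

In a functional assay on HCT-116 cells (Homo sapiens) for antiproliferative activity, read by sulforhodamine B assay, with a stated time of 72 h (a higher number here means a weaker inhibitor, a lower number a stronger inhibitor), compound 1 (`COc1ncc(-c2ccc3ncc(NCc4ccccc4)c(OC)c3c2)cc1NS(=O)(=O)c1ccc(F)cc1F`) gives 16800 nM and compound 2 (`COc1ncc(-c2ccc3ncc(NCC4CCCCC4)c(OC)c3c2)cc1NS(=O)(=O)c1ccc(F)cc1F`) gives 13600 nM, so compound 2 stands level with compound 1 within the scatter. Compound 3 (`CCNc1cnc2ccc(-c3cnc(OC)c(NS(=O)(=O)c4ccc(F)cc4F)c3)cc2c1OC`) carries methyl in place of cyclohexyl on a saturated chain carbon bound to a nitrogen on an aromatic ring. Among the compounds with values here, only one measured step bears on this, a 1.2-fold lower number from compound 1 to compound 2 (0.09 log units; within the scatter), which lies within the scatter. That step exchanged one ring for another and removed none, so it is only a weak guide to the loss of the ring in compound 3. A modest move to a lower number is expected in this assay, with little confidence in its direction. The expected step is a 1.9-fold lower number from compound 2 to compound 3 (0.29 log units; within the scatter). For compound 3 the estimated value is 7000 nM, with an expected range of 1200 nM to 25000 nM.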

Compound 3, half-maximal inhibitory concentration: 1850 nM
Compound 3: the middle estimate sits 3.8-fold (0.58 log units) above what was measured; the range from low to high includes it.
By their numbers in this assay, from the lowest: compound 3; then compounds 2 and 1 (each within the scatter of the next).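

In this assay methyl in place of cyclohexyl on a saturated chain carbon bound to a nitrogen on an aromatic ring gives a 7.4-fold lower number from compound 2 to compound 3 (0.87 log units; beyond the scatter) and methyl in place of phenyl gives a 9.1-fold lower number from compound 1 to compound 3 (0.96 log units; beyond the scatter) in the same read-out. The exchange of one ring for the other, a 1.2-fold lower number from compound 1 to compound 2 (0.09 log units; within the scatter), gave no sign that this position responds to a change of group, whereas the two ring-bearing compounds now stand together and compound 3, without a ring, lies apart from both. No measured information accounts for this difference.

With only one ring-free group among the compounds shown, it remains open whether the number depends on losing the ring or on the size of the group. A longer chain such as propyl or butyl, or hydrogen in place of methyl, would separate these readings, and an amine at the end of the chain would test whether this position tolerates a group of another kind.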